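Chain amine variation on the shared core: compound 4

This account rests on a few compounds, and the source may have more. Where it says the series, first, only, none or still open, it means among the compounds named here.

Within the data shown here, compound 3 `Cc1cc(C)c2ccc(=O)n(CCN)c2n1` gives 33.8 ug/mL in an assay on isolated protein (strain Charles River) for antagonist activity at histamine H2 receptor (Rattus norvegicus) (on this read-out lower numbers stand for an effect already at smaller amounts and higher numbers for an effect only at larger amounts of compound), the highest of the three numbers so far. Compound 1 `COc1cc(C)c2ccc(=O)n(CCN(C)C)c2n1` gives 7.01 ug/mL and compound 2 `Cc1cc(Cl)nc2c1ccc(=O)n2CCN(C)C` gives 9.23 ug/mL; both lie beyond the scatter from compound 3, and the two of them lie within the scatter of each other. Among the measured compounds shown here, the only single-point step measured so far, a 1.3-fold higher number from compound 1 to compound 2 (0.12 log units; within the scatter), concerns the aromatic substituent and says nothing about the chain amine.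

Compound 4 `CCN(CC)CCn1c(=O)ccc2c(C)cc(C)nc21` differs from compound 3 in one place: diethylamino in place of amino on a saturated chain carbon, two bonds along the chain from an aromatic nitrogen. For the measured compounds named here, no measured pair isolates this change. The closest comparison is indirect: compounds 1 and 2 carry a dimethylamino rather than an amino group on the chain, together with a different aromatic substituent, and both sit well below compound 3. If the chain amine accounts for part of that gap, a lower number is expected for compound 4; the unmeasured contribution of the aromatic substituents leaves this uncertain, and ethyl rather than methyl on the nitrogen is untested in this series.

For compound 4 a step of a 3.1-fold lower number from compound 3 to compound 4 (0.49 log units; beyond the scatter) toward a lower number is expected. The estimate for compound 4 in this assay is 11 ug/mL, with a range from 4 ug/mL to 30 ug/mL.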

Compound 4, half-maximal effective concentration: 1.12 ug/mL
Beside the measured number, compound 4's estimate is 9.8-fold (0.99 log units) above it; the measured number lies below the stated range.
By their numbers in this assay, from the lowest: compound 4; then compounds 1 and 2 (each within the scatter of the next); then compound 3.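

In this assay, among these compounds, the chain amine now has a directly measured step, a 30-fold lower number from compound 3 to compound 4 (1.48 log units; beyond the scatter), the first single change to lie beyond the scatter; the aromatic substituent step between compound 1 and compound 2 stayed within it. Among the compounds shown here, the change is compound, since amino with one hydrogen-bond donor and one heavy atom gives way to diethylamino with no donor and five heavy atoms, and the single pair cannot separate the loss of the donor from the added carbon. No supporting evidence bears on what lies behind the step.

Open, as far as these compounds go, is whether ethylamino, or dimethylamino on the core of compound 3, would fall nearer compound 3 or compound 4, which would show how much of the step needs both ethyl groups. Also open, from the compounds shown here alone, is how this position responds to a ring amine such as piperidine or pyrrolidine, and to a longer chain between the aromatic nitrogen and the diethylamino group.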